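The source may report more compounds than this note shows. Statements on the series, on what has been measured and on what is new or still open speak of the compounds shown alone.

Measured compounds in this study:

Compound 1 `C=C1CC[C@H]2C(C)(C)CCC[C@]2(C)[C@H]1C/C=C1/C(=O)OC[C@H]1O` gives 99.2% in a functional assay on RAW264.7 cells (Mus musculus) for inhibition, read by ELISA, with stated times of 1 h and 18 h, tested at 0.1 uM; on this read-out higher numbers stand for a weaker effect at the one concentration tested and lower numbers for a stronger effect.
Compound 2 `C=C1CC[C@H]2C(C)(C)CCC[C@]2(C)[C@H]1C/C=C1\CC(O)OC1=O` gives 99.1% in this assay.

Compound 2 holds the lower of the two numbers, but its nearest neighbour, compound 1, lies within the usual scatter of it, so the two readings are not to be told apart. Both sit close to the top of the percentage scale, which on this read-out means only a faint effect at the single concentration tested.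

Compound 3 `C=C1CC[C@H]2C(C)(C)CCC[C@]2(C)[C@H]1C/C=C1\CC(OCC)OC1=O` is the next structure. It differs from compound 2 by ethyl in place of hydrogen on an oxygen on a saturated carbon.

For the measured compounds named here, no step between measured compounds is available, so nothing from the measured pair says what such a change should do. With compound 2 giving 99.1%, there is little room for a weaker reading, and the step expected in this assay is a number 1.1 percentage points lower from compound 2 to compound 3 (within the scatter), none beyond the scatter. Compound 3 is accordingly estimated at 98%, with a range from 85% to 105%.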

Compound 3, a percentage reported as activity, at one concentration (the size of the read-out at that concentration, not a potency): 102%
For compound 3 the middle estimate is 4 percentage points below the measured one; the range from low to high includes it.
By their numbers in this assay, from the lowest: compounds 2, 1 and 3 (each within the scatter of the next).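

Ethyl in place of hydrogen on an oxygen on a saturated carbon, which turns hydroxy into ethoxy, gives a number 2.9 percentage points higher from compound 2 to compound 3 (within the scatter) in this assay. This first step at this position therefore shows that the free hydroxy and the ethoxy cannot be told apart on this read-out, and that the hydrogen on this oxygen is not needed to keep the reading where it stands, which is close to the top of the scale and so reflects only a faint effect at the single concentration tested. Nothing at hand gives a reason for this result.

From the compounds shown here alone, whether a longer chain on this oxygen, or an amine or a carboxylic acid in place of the hydroxy, would move the reading beyond the scatter remains open. Also open, going by these compounds, is how compound 2 and compound 3 would compare at any other concentration.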